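Swapping Carboxy for Methanesulfonamido: Plasma Protein Binding

The source may report more compounds than this note shows. Statements on the series, on what has been measured and on what is new or still open speak of the compounds shown alone.

Of the compounds shown here, three have so far been measured in an ADME assay on the whole organism (plasma, Macaca fascicularis) for protein binding, read by LC-MS, using equilibrium dialysis and cassette dosing, with a stated time of 24 h, at a dose of 1 mg/kg by the oral route; a lower number here means a smaller unbound share, a higher number a larger unbound share of the compound. Compound 1 `CCCCN(c1nc2ccccc2o1)[C@H](C)c1ccc(-c2ccccc2-c2nnn[nH]2)cc1` gives 0.000713. Compound 2 `CCCCN(c1nc2c(C(=O)O)cccc2o1)[C@H](C)c1ccc(-c2ccccc2-c2nnn[nH]2)cc1` gives 0.000285, and compound 3 `C[C@H](c1ccc(-c2ccccc2-c2nc(=O)o[nH]2)cc1)N(CC1CC1)c1nc2c(C(=O)O)cccc2o1` gives 0.0000851. Compound 2 therefore stands second highest of the three numbers, with compound 1 above it and compound 3 below it. For the measured compounds named here, the only single-place step measured so far runs a 2.5-fold lower number from compound 1 to compound 2 (0.40 log units; beyond the scatter), where a carboxy group replaces a hydrogen on an aromatic carbon. Compound 4 `CCCCN(c1nc2c(NS(C)(=O)=O)cccc2o1)[C@H](C)c1ccc(-c2ccccc2-c2nnn[nH]2)cc1` has not yet been measured; it differs from compound 2 by methanesulfonamido in place of carboxy on an aromatic carbon. Going by the values given here, no measured step covers this exchange directly. The nearest guide is that adding carboxy to compound 1 lowered the number in a 2.5-fold lower number from compound 1 to compound 2 (0.40 log units; beyond the scatter), so taking carboxy away again could move the number part of the way back toward compound 1, while the entering methanesulfonamido group is an unknown. The expected step is a 1.4-fold higher number from compound 2 to compound 4 (0.15 log units; within the scatter), a small rise that may not exceed the scatter. Compound 4 is expected to give 0.0004, within a range from 0.00015 to 0.0011.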

Compound 4, unbound fraction: 0.000203
Compound 4: middle estimate off by 2.0-fold (0.29 log units), on the high side; measured number inside the range.
By their numbers in this assay, from the lowest: compound 3; then compounds 4 and 2 (each within the scatter of the next); then compound 1.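

In this assay, exchanging carboxy for methanesulfonamido on this aromatic carbon gives a 1.4-fold lower number from compound 2 to compound 4 (0.15 log units; within the scatter), so the two groups cannot be told apart here, even though methanesulfonamido brings more heavy atoms and more hydrogen-bond acceptors. Measured against plain hydrogen at the same place, methanesulfonamido gives a 3.5-fold lower number from compound 1 to compound 4 (0.55 log units; beyond the scatter), which shows that the earlier fall in the number is not confined to carboxy: among the groups shown, both substituents at this position give a smaller unbound share than hydrogen. Nothing measured on these compounds bears on why the two groups land so close together.

Still open, going by these compounds, is whether an amine or a methyl ester on this carbon would also lower the number. Also open, on these data alone, is whether the exchange would read the same on the core of compound 3, with its different chain.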